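Hydroxyphenyl series on HT-29: ethoxy to hydroxy again

The source may report more compounds than this note shows. Statements on the series, on what has been measured and on what is new or still open speak of the compounds shown alone.

Compound 1 `COC(=O)N1N=C(c2cccc(O)c2)CC1c1cc(OC)c(OC)c(OC)c1` gives 1350 nM in a functional assay on HT-29 cells (Homo sapiens) for antiproliferative activity, read by MTT assay, with a stated time of 48 h; a higher number here means a weaker inhibitor of growth, a lower number a stronger inhibitor of growth. Compound 2 `CCOc1cccc(C2=NN(C(=O)OC)C(c3cc(OC)c(OC)c(OC)c3)C2)c1` gives 4450 nM and stands highest of the two numbers; the step of a 3.3-fold higher number from compound 1 to compound 2 (0.52 log units; beyond the scatter) lies beyond the scatter. Compound 3 `COC(=O)N1N=C(c2ccc(O)cc2)CC1c1cc(OC)c(OC)c(OC)c1` is not yet measured. It differs from compound 2 by 4-hydroxyphenyl in place of 3-ethoxyphenyl on a carbon with a double bond to nitrogen. Among the measured compounds shown here, only the step from compound 1 to compound 2 bears on this change, and it runs the other way: there ethyl in place of hydrogen on the oxygen raised the number. Undoing the ethyl should therefore lower it, though the ring oxygen also sits elsewhere. Compound 3 is expected near 1500 nM (range 500 nM to 5000 nM), a step of about a 3.0-fold lower number from compound 2 to compound 3 (0.47 log units; beyond the scatter) expected.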

Compound 3, concentration for 50% growth inhibition: 6770 nM
Compound 3: the middle estimate sits 4.5-fold (0.65 log units) below what was measured; the measured number lies above the stated range.
By their numbers in this assay, from the lowest: compound 1; then compounds 2 and 3 (each within the scatter of the next).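

In this assay, a hydroxyl on the aryl group does not by itself bring the lower number: 4-hydroxyphenyl and 3-ethoxyphenyl on this carbon cannot be told apart, with a 1.5-fold higher number from compound 2 to compound 3 (0.18 log units; within the scatter). Where the oxygen sits on the ring does matter, since 4-hydroxyphenyl in place of 3-hydroxyphenyl gives a 5.0-fold higher number from compound 1 to compound 3 (0.70 log units; beyond the scatter). No measured evidence on the series accounts for this difference.

Still open, from the compounds shown here alone, is how an amine or a carboxylic acid in place of the hydroxyl would compare with compound 1. Going by these compounds, a longer chain on the oxygen, beyond the ethyl of compound 2, is equally open.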